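A few compounds are considered here, and "the series" means these few. Any claim that something is new, unique, unknown or untested is made for them only; others in the source may bear on it.

Compound 1 `O=C(CCCCC1CCSS1)Nc1ccccc1Cl`: 4.66%
Compound 2 `O=C(CCCCC(S)CCS)Nc1ccc(F)cc1`: 6.81%
Compound 3 `CC(=O)SCCC(CCCCC(=O)Nc1ccccc1)SC(C)=O`: 3.2%

All three compounds were tested in a functional assay on HO8910 cells (Homo sapiens) for inhibition, read by MTT assay, with a stated time of 24 h, tested at 10 ug/mL; on this read-out lower numbers stand for less inhibition of growth and higher numbers for more inhibition of growth at the one concentration tested. Compound 3, at 3.2%, lies within the usual scatter of both compound 1 and compound 2, so no order can be read among the three. All of them show little inhibition of growth in this assay.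

The next compound is compound 4 `CC(=O)SCCC(CCCCC(=O)Nc1ccc(Cl)cc1)SC(C)=O`, which differs from compound 3 at one place: chloro in place of hydrogen on an aromatic carbon. This is chloro in place of hydrogen on an aromatic carbon, para to a large group. Among the compounds with values here, no measured pair isolates this change, so the expectation rests on weak evidence. Compound 1 also carries chloro on an aromatic carbon, and it gives 4.66%, though it differs from compound 3 elsewhere too. No step beyond the scatter is expected in this assay, and no direction can be assigned with confidence. The expected change is a number 2.8 percentage points higher from compound 3 to compound 4 (within the scatter). For compound 4 the estimated value is 6%, with an expected range of 0% to 18%.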

Compound 4, percent growth inhibition at one concentration: 1.47%
For compound 4 the middle estimate is 4.5 percentage points above the measured one; the measured number falls inside the stated range.
By their numbers in this assay, from the lowest: compounds 4, 3, 1 and 2 (each within the scatter of the next).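

Chloro in place of hydrogen on an aromatic carbon, para to a large group, gives the first step in the series that isolates one change: in this assay the step reads a number 1.7 percentage points lower from compound 3 to compound 4 (within the scatter) and so cannot be told apart from repeat scatter. Phenyl to 4-chlorophenyl therefore leaves this read-out unmoved on the core of compound 3, and inhibition of growth stays small on both sides of the step. Nothing on hand bears on why this step has the size it has.

Open, on these data alone, is whether an amine, a carboxylic acid or a methoxy group at this same place would move the number beyond the scatter. Also open, as far as these compounds go, is whether chloro at this place behaves alike on the side chains of compound 1 and compound 2.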